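Extending the Amide Chain of a Sulfonate Ester Series

A few compounds are considered here, and "the series" means these few. Any claim that something is new, unique, unknown or untested is made for them only; others in the source may bear on it.

Three measured compounds share a core in which an anilide is joined through a sulfonate ester to a second aromatic ring. In a functional assay on HT-29 cells (Homo sapiens) for antiproliferative activity, read by sulforhodamine B assay, with a stated time of 48 h (on this read-out lower numbers stand for stronger inhibition and higher numbers for weaker inhibition), compound 1 `CCCC(=O)Nc1cccc(S(=O)(=O)Oc2ccccc2C(C)C)c1` gives 13000 nM, compound 2 `CC(=O)Nc1ccc(S(=O)(=O)Oc2ccccc2I)cc1` gives 23000 nM, and compound 3 `CC(C)c1ccccc1OS(=O)(=O)c1ccc(NC(=O)CCl)cc1` gives 5600 nM. Compound 2 thus carries the highest number of the three; its separation from compound 1 falls within the scatter of this assay, while its separation from compound 3 lies beyond it, so compound 3 inhibits growth more strongly than compound 2 while compound 1 and compound 2 cannot be ranked.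

Compound 4 `O=C(CCCCl)Nc1ccc(S(=O)(=O)Oc2ccccc2I)cc1` has not yet been measured. It differs from compound 2 in one place: 2-chloroethyl in place of hydrogen on a saturated chain carbon bound to a carbonyl carbon. No step between two measured compounds matches this change, so the expectation rests only on the spread of the three numbers shown. The longer chain of compound 1 sits within the scatter of compound 2, and the chlorine-bearing chain of compound 3 gives the lowest number, so a modest move toward stronger inhibition is expected for compound 4, of size a 2.1-fold lower number from compound 2 to compound 4 (0.32 log units; beyond the scatter), though a result within the scatter of compound 2 would not be surprising. In this assay compound 4 is estimated at 11000 nM, within a range of 4000 nM to 30000 nM.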

Compound 4, half-maximal inhibitory concentration: 9100 nM
The estimate for compound 4 lay 1.2-fold (0.08 log units) above the measured number; measured number inside the range.
By their numbers in this assay, from the lowest: compounds 3, 4, 1 and 2 (each within the scatter of the next, the first and the last beyond it).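

In this assay, putting 2-chloroethyl in place of hydrogen on a saturated chain carbon bound to a carbonyl carbon gives a 2.5-fold lower number from compound 2 to compound 4 (0.40 log units; beyond the scatter) and so counts as a modest change that still clears the usual scatter. Going by these compounds alone, this is the first pair that differs in one place only, so the effect of a change at this position can now be read directly and no longer has to be guessed from the spread of numbers across compounds that differ in several places: here, turning acetamido into ((3-chloropropyl)carbonyl)amino goes with stronger growth inhibition, not weaker. No measurement at hand explains why this single step has the size it has.

Still open, as far as these compounds go, is whether a plain propyl group, carrying no chlorine, would give the same step in place of 3-chloropropyl, or whether an amine or a carboxylic acid in place of the chlorine would keep it. Also open, from the compounds shown here alone, is whether the same change would have a similar effect on the core of compound 1 or compound 3, since this one pair shows it on the core of compound 2 alone.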